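The source may report more compounds than this note shows. Statements on the series, on what has been measured and on what is new or still open speak of the compounds shown alone.

Working notes on the series.

Compound 1 `Nc1ncnc2c1ncn2CC(O)C(=O)OC1CCCCC1` gives 100 ug/mL in a functional assay on Vero cells (Chlorocebus sabaeus) for cytotoxicity; a higher number here means that more compound is tolerated, a lower number that less compound is tolerated. Compound 2 `Nc1ncnc2c1ncn2CC(O)C(=O)OCc1ccco1` gives 40 ug/mL in this assay. The step between them is a 2.5-fold lower number from compound 1 to compound 2 (0.40 log units; beyond the scatter). Within the data shown here, compound 2 thus stands lowest of the two numbers measured so far, with compound 1 as its nearest neighbour at a higher value.

Compound 3 `CC(C)(C)OC(=O)C(O)Cn1cnc2c(N)ncnc21` is not yet measured. It differs from compound 2 as follows: tert-butyl in place of (furan-2-yl)methyl on an oxygen next to a carbonyl group. Among the measured compounds shown here, the only measured step that bears on this change is a 2.5-fold lower number from compound 1 to compound 2 (0.40 log units; beyond the scatter), which exchanged one group on the same oxygen for another and moved the number by a modest amount. For the measured compounds named here, that step suggests the group on this oxygen can shift the read-out beyond the scatter, though no measured pair contains tert-butyl. A rise back toward the value of compound 1 is the expectation for compound 3, because in this assay compound 1 gives 100 ug/mL. The expected step is a 1.8-fold higher number from compound 2 to compound 3 (0.24 log units; within the scatter), with the estimate for compound 3 at 70 ug/mL and a range from 30 ug/mL to 160 ug/mL.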

Compound 3, minimum cytotoxic concentration: > 400 ug/mL
Compound 3: no number, only a limit; the forecaster's own chance of this, stated with the estimate: 10%; middle value at least 5.7-fold (0.75 log units) away from the limit.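

For compound 3 the read-out is a limit and not a number: the limit of > 400 ug/mL in this assay, at which 1 of the 3 values shown sits. Exchange of the group on an oxygen next to a carbonyl group can move the read-out much further than the earlier step showed: tert-butyl in place of (furan-2-yl)methyl gives an at least 10-fold higher number from compound 2 to compound 3 (1.00 log units; beyond the scatter), and tert-butyl in place of cyclohexyl gives an at least 4.0-fold higher number from compound 1 to compound 3 (0.60 log units; beyond the scatter). Among the three compounds, the only group without a ring, tert-butyl, carries the highest reading in this assay, a pattern that rests on compound 3 alone.

From the compounds shown here alone, how far the read-out of compound 3 lies past its limit remains open, and so does the full size of both steps. Also open, going by these compounds, is whether an unbranched butyl, a methyl or a free carboxylic acid in place of the ester would follow compound 3 or the two ring-bearing compounds.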